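The source may report more compounds than this note shows. Statements on the series, on what has been measured and on what is new or still open speak of the compounds shown alone.

Working notes on the series. Compound 1 `OC[C@H]1O[C@@H](n2cnc3c(SC4CCCCC4)ncnc32)[C@H](O)[C@@H]1O` carries a cyclohexylsulfanyl group on the shared core and gives 6310 nM in an assay on isolated protein for binding affinity to Equilibrative nucleoside transporter 1 (Homo sapiens); on this read-out lower numbers stand for stronger inhibition and higher numbers for weaker inhibition. Compound 2 `OC[C@H]1O[C@@H](n2cnc3c(CSc4ccccc4Br)ncnc32)[C@H](O)[C@@H]1O` gives 2400 nM in this assay, and the step of a 2.6-fold lower number from compound 1 to compound 2 (0.42 log units; beyond the scatter) is modest. Compound 3 `O=[N+]([O-])c1cccc(SCc2ncnc3c2ncn3[C@@H]2O[C@H](CO)[C@@H](O)[C@H]2O)c1` gives 4.79 nM; the step of a 500-fold lower number from compound 2 to compound 3 (2.70 log units; beyond the scatter) is by far the largest in the set. Compound 3 therefore holds the lowest number of the three, with compound 2 nearest and compound 1 furthest, both beyond the scatter.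

Compound 4 `OC[C@H]1O[C@@H](n2cnc3c(CSc4ccc(Br)cc4)ncnc32)[C@H](O)[C@@H]1O` is not yet measured. Its change from compound 3 is 4-bromophenyl in place of 3-nitrophenyl on a sulfur. The step that bears on it most directly is the aryl swap on the same sulfur, where a 500-fold lower number from compound 2 to compound 3 (2.70 log units; beyond the scatter) shows that the ring attached to the sulfur can move the number a great deal; the step of a 2.6-fold lower number from compound 1 to compound 2 (0.42 log units; beyond the scatter) is less relevant, as it changes the whole sulfur-bearing substituent. Whether a bromine at the 4-position of the ring behaves like the 2-bromophenyl of compound 2 is not shown by any measured pair.

For compound 4 the number in this assay is expected to rise, with a 100-fold higher number from compound 3 to compound 4 (2.02 log units; beyond the scatter) as the estimated step, because a 500-fold lower number from compound 2 to compound 3 (2.70 log units; beyond the scatter) shows how much a bromophenyl lost against the nitrophenyl. Compound 4 is thus estimated at 500 nM, with a range of 50 nM to 5000 nM.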

Compound 4, half-maximal inhibitory concentration: 178 nM
The estimate for compound 4 lay 2.8-fold (0.45 log units) above the measured number; the range from low to high includes it.
By their numbers in this assay, from the lowest: compound 3; then compound 4; then compound 2; then compound 1.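

In this assay, among the compounds shown here, a 13-fold lower number from compound 2 to compound 4 (1.13 log units; beyond the scatter) comes with a 4-bromophenyl group taking over from a 2-bromophenyl group on the sulfur, so the place of the bromine on the ring alone moves the number well beyond the scatter, which no earlier pair could show; the same placement also turns the modest 2.6-fold lower number from compound 1 to compound 2 (0.42 log units; beyond the scatter) into a 35-fold lower number from compound 1 to compound 4 (1.55 log units; beyond the scatter) when the substituent replaces cyclohexylsulfanyl. Even so, the 4-bromophenyl ring does not match the 3-nitrophenyl ring, as a 37-fold higher number from compound 3 to compound 4 (1.57 log units; beyond the scatter) shows, so a bromophenyl on this sulfur can reach a much lower number than compound 2 suggested, yet compound 3 keeps the lowest number of the four. No measurement at hand explains why these ring changes move the number as they do.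

From the compounds shown here alone, the step between compound 3 and compound 4 changes both the group and its place on the ring, so the share of each stays open, and 3-bromophenyl or 4-nitrophenyl on the same sulfur would separate them. Also open, going by these compounds, is how the number responds to an amine or a carboxylic acid on this ring, or to a longer chain between the sulfur and the ring.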